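The source may report more compounds than this note shows. Statements on the series, on what has been measured and on what is new or still open speak of the compounds shown alone.

Measured compounds:
compound 1 `COc1cccc(/C=C2\CCC/C(=C\c3cccc(O)c3)C2=O)c1OC` gives 8500 nM
compound 2 `COc1cccc(/C=C2\CCC/C(=C\c3ccc(O)cc3)C2=O)c1OC` gives > 20000 nM (a limit)
compound 3 `COc1cccc(/C=C2\CCC/C(=C\c3cccc(Cl)c3Cl)C2=O)c1OC` gives 19300 nM

In a functional assay on HT-1080 cells (Homo sapiens) for cytotoxicity, read by MTT assay, with a stated time of 72 h (a lower number here means a stronger inhibitor, a higher number a weaker inhibitor), compound 3 at 19300 nM holds the higher of the two actual numbers, and its nearest neighbour is compound 1 at 8500 nM. Compound 2 is known only as a limit, > 20000 nM.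

The unmeasured compound 4 `COc1cc(/C=C2\CCC/C(=C\c3cccc(OC)c3OC)C2=O)ccc1O` differs from compound 3 as follows: 4-hydroxy-3-methoxyphenyl in place of 2,3-dichlorophenyl on a double-bonded chain carbon bound to a double-bonded ring carbon. The change is 4-hydroxy-3-methoxyphenyl in place of 2,3-dichlorophenyl on a double-bonded chain carbon bound to a double-bonded ring carbon.

For the measured compounds named here, three measured steps concern this place. The step of a 2.3-fold higher number from compound 1 to compound 3 (0.36 log units; beyond the scatter) is modest, the step of an at least 2.3-fold higher number from compound 1 to compound 2 (0.37 log units; beyond the scatter) is at least modest, and the step of an at least 1.0-fold lower number from compound 2 to compound 3 (0.01 log units; that floor lies within the scatter) has a floor within the scatter. Compound 2 shares the 4-hydroxy group of compound 4 and shows no separation from compound 3, so only a small shift is expected, with no change beyond the scatter the likeliest outcome. The estimated change in this assay is a 1.5-fold lower number from compound 3 to compound 4 (0.17 log units; within the scatter). For compound 4 the expected value is 13000 nM, with an estimated range of 5500 nM to 26000 nM.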

Compound 4, half-maximal inhibitory concentration: 5900 nM
Compound 4: middle estimate off by 2.2-fold (0.34 log units), on the high side; low and high end bracket the measured number.
By their numbers in this assay, from the lowest: compounds 4 and 1 (each within the scatter of the next); then compound 3. At a limit, above all of these: compound 2.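

In this assay, 4-hydroxy-3-methoxyphenyl in place of 2,3-dichlorophenyl brings a 3.3-fold lower number from compound 3 to compound 4 (0.51 log units; beyond the scatter), while the same group in place of 3-hydroxyphenyl brings a 1.4-fold lower number from compound 1 to compound 4 (0.16 log units; within the scatter), which stays within the scatter. Methoxy in place of hydrogen on an aromatic carbon, with the 4-hydroxy group kept, brings an at least 3.3-fold lower number from compound 2 to compound 4 (0.53 log units; beyond the scatter), so a 4-hydroxy group does not by itself settle the outcome at this place. That step is a floor, since compound 2 is known only as a limit: the limit of > 20000 nM in this assay, at which 1 of the 4 values shown sits.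

Whether the methoxy group alone carries this shift stays open, since a phenyl group bearing only methoxy is not among the compounds shown. The compounds shown also leave open how an amine or a carboxylic acid on this aromatic ring would read.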